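The compounds below may be only part of what the source reports. "The series", "measured", "known", "first", "only" and "open" are said of these compounds alone.

Working notes on the series.

Compound 1 `Cc1nn(-c2ncnc3nc[nH]c23)c2c1C(OCc1cc(F)cc3c1OCOC3)CC(=O)N2` gives the lowest number of the three measured compounds in a functional assay on HEK293 cells for agonist activity at G-protein coupled receptor 39 (Homo sapiens), read by scintillation proximity assay and inositol phosphate accumulation, with a stated time of 75 min (on this read-out lower numbers stand for an effect already at smaller amounts and higher numbers for an effect only at larger amounts of compound), with compound 1 at 30 nM. Going by the values given here, compound 2 `Cc1nn(-c2ncnc3nc[nH]c23)c2c1C(OC(=O)c1ccc(F)cc1)CC(=O)N2` gives 245 nM, and compound 3 `Cc1nn(-c2ncnc3nc[nH]c23)c2c1C(C(=O)NCc1ccccc1)CC(=O)N2` gives 2930 nM; the one measured step, a 12-fold higher number from compound 2 to compound 3 (1.08 log units; beyond the scatter), concerns the exchange of the ester link for an amide link on the saturated ring carbon and not the aromatic end of the side chain.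

Compound 4 `Cc1nn(-c2ncnc3nc[nH]c23)c2c1C(OCc1ccccc1F)CC(=O)N2` differs from compound 1 as follows: a group of 7 heavy atoms (6 carbon, 1 fluorine; one six-membered aromatic ring of carbon only) in place of a group of 11 heavy atoms (8 carbon, 2 oxygen, 1 fluorine; one six-membered non-aromatic ring with 2 hetero atoms, one six-membered aromatic ring of carbon only), on a saturated chain carbon bound to an oxygen on a saturated carbon. Among the compounds with values here, no measured step probes this exchange; the only indirect hint is that compound 1 and compound 2, both carrying an oxygen-linked aromatic group, differ by a margin beyond the scatter, so the identity of that aromatic end does matter here. The 2-fluorophenyl group retains the fluorine and the aromatic ring of compound 1 but loses the fused six-membered ring with two hetero atoms. A moderate rise in the number is therefore expected, estimated at a 3.7-fold higher number from compound 1 to compound 4 (0.56 log units; beyond the scatter). For compound 4 the value in this assay is expected at 110 nM, within 30 nM to 450 nM.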

Compound 4, half-maximal effective concentration: 78 nM
For compound 4 the middle estimate is 1.4-fold (0.15 log units) above the measured one; low and high end bracket the measured number.
By their numbers in this assay, from the lowest: compound 1; then compound 4; then compound 2; then compound 3.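

In this assay, the oxygen-linked side chain keeps most of the low number of compound 1 without its six-membered non-aromatic ring with 2 hetero atoms, at a cost of only a 2.6-fold higher number from compound 1 to compound 4 (0.41 log units; beyond the scatter). On the saturated ring carbon, (2-fluorobenzyl)oxy in place of benzylcarbamoyl gives a 38-fold lower number from compound 3 to compound 4 (1.57 log units; beyond the scatter), a large step that shows this side chain tolerates the amide-linked group far less well. On the oxygen itself, 2-fluorobenzyl in place of (4-fluorophenyl)carbonyl gives a 3.1-fold lower number from compound 2 to compound 4 (0.50 log units; beyond the scatter), although this exchange alters both the link and the place of the fluorine, so neither can be credited alone.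

As far as these compounds go, what a plain benzyl group, or a methoxy or nitrile group in place of the fluorine of 2-fluorobenzyl, would give remains open. Nothing at hand bears on the reason for these steps.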